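The source may hold more compounds than are shown below. What is called first, only, known or untested is meant among the compounds shown, and "the series" means these compounds.

Measured compounds:
compound 1, `CN(C)/C=C/N1CCN(CC(=O)Nc2ccc(-c3nc(-c4ccccc4)c(-c4ccccc4)n3C)cc2)CC1`, 19.4%
compound 2, `Cn1c(-c2ccc(NC(=O)CN3CCN(c4ccccc4)CC3)cc2)nc(-c2ccccc2)c1-c1ccccc1`, 59.6%
compound 3, `Cc1ccc(CN2CCN(CC(=O)Nc3ccc(-c4nc(-c5ccccc5)c(-c5ccccc5)n4C)cc3)CC2)cc1`, 26%

In a functional assay on MCF7 cells (Homo sapiens) for cytotoxicity, read by MTT assay, with a stated time of 24 h, tested at 16 ug/mL (a lower number here means a weaker effect, a higher number a stronger effect of the compound at the concentration tested), compound 3 gives 26%, the second highest of the three numbers. Its nearest neighbour is compound 1: the step of a number 6.6 percentage points higher from compound 1 to compound 3 (within the scatter) stays within the scatter, so the two cannot be ranked against each other. Its furthest neighbour is compound 2, from which it is separated by the large step of a number 33.6 percentage points lower from compound 2 to compound 3 (beyond the scatter). The other measured step, a number 40.2 percentage points higher from compound 1 to compound 2 (beyond the scatter), is also large.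

Compound 4, `COc1ccc(CN2CCN(CC(=O)Nc3ccc(-c4nc(-c5ccccc5)c(-c5ccccc5)n4C)cc3)CC2)cc1`, differs from compound 3 in one place: methoxy in place of methyl on an aromatic carbon. Every measured step, by contrast, exchanged the whole group on the amine nitrogen in the ring; none of them altered a substituent on an aromatic carbon of a six-membered aromatic ring of carbon only. Those steps therefore do not bear directly on the change from compound 3 to compound 4. Among the compounds with values here, the only comparison in which the group on the ring nitrogen kept a similar shape, compound 1 to compound 3, moved the number within the scatter. The change here is smaller still. Compound 4 is therefore expected to show no step beyond the scatter, a number 2 percentage points higher from compound 3 to compound 4 (within the scatter), and its value in this assay is estimated at 28%, within 14% to 44%.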

Compound 4, a percentage reported as activity, at one concentration (the size of the read-out at that concentration, not a potency): 12%
For compound 4 the middle estimate is 16 percentage points above the measured one, outside the stated range (below it).
By their numbers in this assay, from the lowest: compounds 4, 1 and 3 (each within the scatter of the next, the first and the last beyond it); then compound 2.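

Within the data shown here, on an aromatic carbon, para to a large group, the earlier compounds offered no comparison, and here the exchange of methyl for methoxy in this assay proves not to be neutral (a number 14 percentage points lower from compound 3 to compound 4 (beyond the scatter)), a modest step from an exchange of one small substituent. The new group leaves the number close to that of a very different group on the ring nitrogen (a number 7.4 percentage points lower from compound 1 to compound 4 (within the scatter)), while compound 2 with its phenyl group remains clearly apart (a number 47.6 percentage points lower from compound 2 to compound 4 (beyond the scatter)), so that compound 2 stays the highest of the four and 4-methoxybenzyl does not close the gap. Nothing available explains why the methoxy compound gives the lower number.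

Going by these compounds, whether the step belongs to methoxy in particular stays open, since a chlorine, a hydroxyl or a longer ether such as ethoxy at this place could lie on either side of compound 3. Also open, on these data alone, is whether a methoxy group on the phenyl ring of compound 2 would lower the number in the same way, and whether the weaker effect seen at this single concentration would also appear at other concentrations.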